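Compound 3 to compound 4: one open-chain group for another

The source may hold more compounds than are shown below. What is called first, only, known or untested is meant among the compounds shown, and "the series" means these compounds.

In a functional assay on HepG2 cells (Homo sapiens) for inhibition, read by MTT assay, with a stated time of 48 h (on this read-out higher numbers stand for weaker inhibition and lower numbers for stronger inhibition), compound 1 (`CCOC(=O)C1=C(N/C=N/c2cccnc2Cl)Nc2[nH]nc(C)c2C1c1ccc(N(C)C)cc1`) gives 4890 nM and compound 2 (`CCOC(=O)C1=C(N/C=N/c2ccccn2)Nc2[nH]nc(C)c2C1c1ccc(N(C)C)cc1`) gives 26200 nM as the two lower numbers. Compound 3 (`CCOC(=O)C(=NNC1=C(C(=O)OCC)C(c2ccc(N(C)C)cc2)c2c(C)n[nH]c2N1)C(=O)OCC`) gives 80800 nM as the highest number of the three and is the weakest so far, with its steps to both other compounds beyond the scatter.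

The next compound is compound 4 (`CCOC(=O)C1=C(N/N=C(/C(C)=O)C(=O)OCC)Nc2[nH]nc(C)c2C1c1ccc(N(C)C)cc1`), not yet measured in this assay and carrying this change: a group of 10 heavy atoms (6 carbon, 1 nitrogen, 3 oxygen; no ring) in place of a group of 12 heavy atoms (7 carbon, 1 nitrogen, 4 oxygen; no ring), on an amine nitrogen (the rest of the structure stays the same).

The measured steps bear on this only indirectly. The modest 3.1-fold higher number from compound 2 to compound 3 (0.49 log units; beyond the scatter) and the large 17-fold higher number from compound 1 to compound 3 (1.22 log units; beyond the scatter) both replace a group holding a six-membered aromatic ring with the open-chain group of compound 3. The modest 5.4-fold higher number from compound 1 to compound 2 (0.73 log units; beyond the scatter) exchanges one ring-bearing group for another. Among the measured compounds shown here, no measured step exchanges one open-chain group for another, so direction is poorly supported. With no ring on either side of the change, a step smaller than those is expected, probably within the scatter, with only a slight lean to a lower number since compound 3 stands highest at 80800 nM in this series.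

The expected step is a 1.3-fold lower number from compound 3 to compound 4 (0.13 log units; within the scatter) on this estimate. For compound 4 the estimated value is 60000 nM with an expected range from 25000 nM to 140000 nM in this assay when measured.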

Compound 4, half-maximal inhibitory concentration: > 100000 nM
Compound 4 ended at the assay's limit (the forecaster's own chance of this, stated with the estimate: 10%); at least 1.6-fold (0.22 log units) between middle value and limit.
By their numbers in this assay, from the lowest: compound 1; then compound 2; then compound 3. At a limit, above all of these: compound 4.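

In this assay compound 4 reaches a limit of the assay, > 100000 nM, which is a limit and not a number: the limit of > 100000 nM in this assay, at which 1 of the 4 values shown sits. Among the compounds shown here, the first exchange of one open-chain group for another on this amine nitrogen gives an at least 1.2-fold higher number from compound 3 to compound 4 (0.09 log units; that floor lies within the scatter), so the floor of this step does not separate the two compounds, and neither its true size nor its direction can be settled. The floors against the ring-bearing groups give an at least 3.8-fold higher number from compound 2 to compound 4 (0.58 log units; beyond the scatter) and an at least 20-fold higher number from compound 1 to compound 4 (1.31 log units; beyond the scatter), and among the four compounds shown, both open-chain groups stand at higher numbers than both groups with a six-membered aromatic ring, with no compound going against this.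

As far as these compounds go, it remains open whether any group without a ring on this nitrogen can give a number as low as the ring-bearing groups, for instance a plain alkyl chain, an amine or a carboxylic acid. From the compounds shown here alone, it also remains open how far the number would fall with other aromatic groups here, such as a phenyl ring or a pyridine ring carrying fluorine or methoxy.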